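Trifluoromethoxy for Cyano on the Benzyl Ring

This account rests on a few compounds, and the source may have more. Where it says the series, first, only, none or still open, it means among the compounds named here.

Compound 1 `O=C(O)CCCCCCN1C(=O)CC[C@@H]1CC[C@@H](O)Cc1cccc(-c2ccccc2)c1`: 337 nM
Compound 2 `N#Cc1cccc(C[C@H](O)CC[C@H]2CCC(=O)N2CCCCCCC(=O)O)c1`: 388 nM

In an assay on HEK293 cells for binding affinity to prostaglandin E2 receptor EP4 subtype (Rattus norvegicus) (on this read-out lower numbers stand for stronger inhibition and higher numbers for weaker inhibition), compound 1 gives 337 nM, while compound 2 gives 388 nM. Compound 2 therefore sits alongside compound 1, the two being separated only by a 1.2-fold higher number from compound 1 to compound 2 (0.06 log units; within the scatter), a gap that lies within the scatter of this read-out. The next compound, compound 3 `O=C(O)CCCCCCN1C(=O)CC[C@@H]1CC[C@@H](O)Cc1cccc(OC(F)(F)F)c1`, differs from compound 2 by trifluoromethoxy in place of cyano on an aromatic carbon. Among the measured compounds shown here, the only measured step that bears on this change is the one from compound 1 to compound 2, which also exchanged one group for another at the same aromatic carbon and moved the number by a 1.2-fold higher number from compound 1 to compound 2 (0.06 log units; within the scatter). With that step inside the scatter, compound 3 is expected to show a 1.1-fold lower number from compound 2 to compound 3 (0.04 log units; within the scatter), a step not expected to exceed the scatter in either direction. Compound 3 is accordingly estimated at 350 nM, with a range from 150 nM to 800 nM.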

Compound 3, half-maximal inhibitory concentration: 59 nM
For compound 3 the middle estimate is 5.9-fold (0.77 log units) above the measured one, and the stated range ends above it.
By their numbers in this assay, from the lowest: compound 3; then compounds 1 and 2 (each within the scatter of the next).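

In this assay this aromatic carbon turns out to be sensitive to the group it carries: the exchange between phenyl and cyano stayed within the scatter, whereas trifluoromethoxy gives a 6.6-fold lower number from compound 2 to compound 3 (0.82 log units; beyond the scatter) and a 5.7-fold lower number from compound 1 to compound 3 (0.76 log units; beyond the scatter). Cyano and trifluoromethoxy have the same count of hydrogen-bond donors and acceptors and carry no net charge, so those counts do not separate compound 2 from compound 3. No measurement shown here accounts for the stronger inhibition seen with compound 3.

On these data alone, it remains open whether a trifluoromethyl group, a methoxy group or a chlorine atom on this carbon would match trifluoromethoxy. As far as these compounds go, it is equally open whether trifluoromethoxy would give a similar number on another carbon of the same ring.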